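Ring methyl on the shared core: forward estimate

The source may report more compounds than this note shows. Statements on the series, on what has been measured and on what is new or still open speak of the compounds shown alone.

Measured compounds:
Compound 1 `CC(C(=O)NCc1cccc(Cl)c1)N1C(=O)CCC1=O`: 82 mg/kg
Compound 2 `CC(C(=O)NCc1cccc(F)c1)N1C(=O)CCC1=O`: 77.4 mg/kg

For the measured compounds named here, in a functional assay on the whole organism (strain Albino Swiss CD1) with Mus musculus as the target, in the maximal electroshock model (a lower number here means that less compound is needed, a higher number that more compound is needed for the effect), compound 2 and compound 1 stand within the scatter of each other; the single measured step, a 1.1-fold lower number from compound 1 to compound 2 (0.03 log units; within the scatter), concerns a halogen on the aromatic ring only. Compound 3 `CC1CC(=O)N(C(C)C(=O)NCc2cccc(F)c2)C1=O` differs from compound 2 by methyl in place of hydrogen on a saturated ring carbon. Going by the values given here, no measured step touches this part of the shared core, so the halogen step gives no guidance on size or direction. With nothing to suggest a shift, the step from compound 2 to compound 3 is expected to fall within the scatter, a 1.0-fold lower number from compound 2 to compound 3 (0.00 log units; within the scatter). Compound 3 is therefore estimated at 77 mg/kg, with a range of 40 mg/kg to 150 mg/kg.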

Compound 3, dose for half-maximal effect: 130 mg/kg
Compound 3: the middle estimate sits 1.7-fold (0.23 log units) below what was measured; low and high end bracket the measured number.
By their numbers in this assay, from the lowest: compounds 2, 1 and 3 (each within the scatter of the next).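

In this assay, the saturated ring carbon two ring bonds from the ring nitrogen accepts a methyl in place of hydrogen with a 1.7-fold higher number from compound 2 to compound 3 (0.23 log units; within the scatter). For the compounds shown here, this is the first reading on the shared core itself rather than on the aromatic halogen, and with one heavy atom added, the step stays within the scatter. No measurement at hand bears on the reason for this result. Open, from the compounds shown here alone, is whether an ethyl group, a phenyl ring or an amine on this carbon would also stay within the scatter. Also open, going by these compounds, is whether methyl behaves the same alongside the chloro group of compound 1.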